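Methoxy on the Phenyl Arm: Expectation for Compound 4

The source may report more compounds than this note shows. Statements on the series, on what has been measured and on what is new or still open speak of the compounds shown alone.

Three compounds share one core and are tested in a functional assay on U-87MG ATCC cells (Homo sapiens) for cytotoxicity, read by MTT assay, with a stated time of 72 h; a higher number here means a weaker inhibitor, a lower number a stronger inhibitor. Compound 1 `COc1cc2c(Oc3ccc(NC(=O)c4cc(-c5ccccc5)nc5ccccc45)cc3F)ccnc2cc1OCCCN1CCCCC1` gives 1490 nM. Compound 2 `COc1cc2c(Oc3ccc(NC(=O)c4cc(-c5ccc(C)cc5)nc5ccccc45)cc3F)ccnc2cc1OCCCN1CCCC1` carries a methyl on its phenyl arm, and in this assay compound 2 gives "not determined" (no result reported). Compound 3 `COc1cc2c(Oc3ccc(NC(=O)c4cc(-c5ccccc5)nc5ccc(F)cc45)cc3F)ccnc2cc1OCCCN1CCCCC1` gives 690 nM, the lowest of the two numbers on hand; its nearest neighbour is compound 1, and the step of a 2.2-fold lower number from compound 1 to compound 3 (0.33 log units; beyond the scatter) is modest, though beyond the scatter.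

Compound 4 `COc1ccc(-c2cc(C(=O)Nc3ccc(Oc4ccnc5cc(OCCCN6CCCCC6)c(OC)cc45)c(F)c3)c3cc(F)ccc3n2)cc1` differs from compound 3 in a single place: methoxy in place of hydrogen on an aromatic carbon. Going by the values given here, no measured step touches this position. Among the compounds with values here, the only step in hand, from compound 1 to compound 3, concerns a fluoro on a different ring, and compound 2, which carries a methyl at the corresponding site, has no number to compare. With nothing pointing in either direction, the expectation is a step of no size beyond the scatter, a 1.1-fold lower number from compound 3 to compound 4 (0.03 log units; within the scatter). Compound 4 is therefore estimated at 650 nM, within a range from 250 nM to 1700 nM.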

Compound 4, half-maximal inhibitory concentration: 1100 nM
For compound 4 the middle estimate is 1.7-fold (0.23 log units) below the measured one; low and high end bracket the measured number.
By their numbers in this assay, from the lowest: compounds 3, 4 and 1 (each within the scatter of the next, the first and the last beyond it).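

In this assay, going by these compounds alone, this is the first reading at this position of the phenyl arm, and the change from phenyl to 4-methoxyphenyl gives a 1.6-fold higher number from compound 3 to compound 4 (0.20 log units; within the scatter). A methoxy on this ring, para to a large group, therefore fits without a change that can be told apart from ordinary assay noise, so this position can carry at least this small added group. No measurement here offers an explanation for this result.

Still open, going by these compounds, is whether the same position would accept a different group, such as a hydroxyl, an amine, a carboxylic acid or a longer chain like butoxy. Also open, on these data alone, is whether methoxy would give a similar result on the shared core without the fluoro that compound 3 and compound 4 carry.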